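The source may report more compounds than this note shows. Statements on the series, on what has been measured and on what is new or still open speak of the compounds shown alone.

Measured in a functional assay on MDA-MB-231 cells (Homo sapiens) for antiproliferative activity, read by MTT assay, with a stated time of 24 h; a lower number here means a stronger inhibitor, a higher number a weaker inhibitor:
- Compound 1 `CCCCc1oc2ccccc2c1C(=O)c1ccc(OCC(=O)NC(C)C)cc1`: > 50000 nM (a limit of the assay)
- Compound 2 `CCCCc1oc2ccccc2c1C(=O)c1ccc(OCCCC(=O)N2CCCCC2)cc1`: 36000 nM

For the measured compounds named here, compound 2 holds the only true number so far. Compound 3 `CCCCc1oc2ccccc2c1C(=O)c1ccc(OCCCC(=O)N[C@@H](C)c2ccccc2)cc1` differs from it as follows: (1-phenylethyl)amino in place of piperidin-1-yl on a carbonyl carbon. Going by the values given here, the only measured step, an at least 1.3-fold lower number from compound 1 to compound 2 (0.14 log units; that floor lies within the scatter), also changes the group on the carbonyl, but it rests on the limit of > 50000 nM in this assay, at which 1 of the 2 values shown sits, and its floor lies within the scatter. It therefore gives no firm guide to size or direction. The expected change in this assay is a 1.2-fold lower number from compound 2 to compound 3 (0.08 log units; within the scatter), with no step beyond the scatter anticipated. Compound 3 is estimated at 30000 nM, with an expected range of 12000 nM to 60000 nM.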

Compound 3, half-maximal inhibitory concentration: > 50000 nM
Compound 3 gave a limit, no number (the forecaster's own chance of this, stated with the estimate: 30%); middle value at least 1.6-fold (0.22 log units) away from the limit.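

In this assay, the carbonyl carbon takes (1-phenylethyl)amino in place of piperidin-1-yl with an at least 1.3-fold higher number from compound 2 to compound 3 (0.14 log units; that floor lies within the scatter). Compound 3 gives > 50000 nM, which is a limit of the assay. The aromatic ring and amide hydrogen that enter here therefore give no lower number than compound 2, and the size of the upward step remains unknown, with the series now mostly at the limit: the limit of > 50000 nM in this assay, at which 2 of the 3 values shown sit.

Compound 2 gives 36000 nM. As far as these compounds go, it remains open whether a carboxylic acid or a morpholin-4-yl group on this carbonyl carbon would give a clearly lower number. From the compounds shown here alone, the opposite configuration of the 1-phenylethyl stereocentre also remains open.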